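A swap of phenyl groups at the assay's limit

This account rests on a few compounds, and the source may have more. Where it says the series, first, only, none or still open, it means among the compounds named here.

In an ADME assay on K562/A02 cells (Homo sapiens) for cytotoxicity, read by MTT assay, with a stated time of 48 h (on this read-out lower numbers stand for stronger inhibition and higher numbers for weaker inhibition), compound 1 (`COc1cc2c(cc1OC)CN(CCn1cc(COc3cccc4ccccc34)nn1)CC2`) gives > 100000 nM as a limit of the assay and not a number. Compound 2 (`CCc1ccc(OCc2cn(CCN3CCc4cc(OC)c(OC)cc4C3)nn2)cc1`) gives > 100000 nM as a limit too, so it has no exact value. Compound 3 (`COc1cc2c(cc1OC)CN(CCn1cc(COc3ccc(C)c(C)c3)nn1)CC2`) has not been measured. It carries 3,4-dimethylphenyl in place of 4-ethylphenyl on an oxygen on a saturated carbon, and the two compounds have the same atoms, joined differently (3,4-dimethylphenyl in place of 4-ethylphenyl on an oxygen on a saturated carbon). For the measured compounds named here, the one measured step at this place is a step that the two limits leave unreadable from compound 1 to compound 2, with 4-ethylphenyl in place of naphthalen-1-yl. It offers no size to carry over, and the overall picture is the limit of > 100000 nM in this assay, at which 2 of the 2 values shown sit, with no exact value yet. In this assay no step beyond the usual scatter is therefore expected, in either direction. The estimated change is a number no higher from compound 2 to compound 3 (the limit leaves the size open), and a report of only a limit is the likeliest outcome. Compound 3 is expected at about 100000 nM, with an estimated range from 30000 nM to 200000 nM as the likely span.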

Compound 3, half-maximal inhibitory concentration: > 100000 nM
Compound 3 was reported as a limit; the forecaster's own chance of this, stated with the estimate: 80%; the middle value sits exactly at the limit.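

For the compounds shown here, compound 1, compound 2 and compound 3 all sit at the same limit in this assay, and no step among them can be read, whether from naphthalen-1-yl or from 4-ethylphenyl. What stays open is the true strength of each compound, and whether any group at this place moves the read-out at all: the limit of > 100000 nM in this assay, at which 3 of the 3 values shown sit.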